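This account rests on a few compounds, and the source may have more. Where it says the series, first, only, none or still open, it means among the compounds named here.

In a functional assay on K562 cells (Homo sapiens) for cytotoxicity, read by trypan blue exclusion, with a stated time of 96 h (on this read-out higher numbers stand for weaker inhibition and lower numbers for stronger inhibition), compound 1 `COc1cc(OC)c(/C=C/S(=O)(=O)Nc2ccc(F)c(N)c2)c(OC)c1` reads 5000 nM. Compound 2 `COc1ccc(NS(=O)(=O)/C=C/c2c(F)c(F)c(F)c(F)c2F)cc1F` reads 10000 nM, within the scatter of compound 1. Compound 3 `COc1ccc(NS(=O)(=O)/C=C/c2c(F)cc(F)cc2F)cc1` reads 15000 nM, a higher number than compound 1 and beyond the scatter. Compound 1 therefore shares the low end of this small set with compound 2.

Compound 4 `COc1cc(OC)c(/C=C/S(=O)(=O)Nc2ccc(OC)c(N)c2)c(OC)c1` keeps the core of compound 1 and changes one group: methoxy in place of fluoro on an aromatic carbon. This is methoxy in place of fluoro on an aromatic carbon, ortho to an amino group and para to a large group. Among the compounds with values here, no measured pair isolates this change. Within the data shown here, compound 2 and compound 3 also carry a methoxy group, but they lack the amino group and differ from compound 1 in more than one place, so they offer no step to carry over.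

In this assay the change is still expected to give stronger inhibition, well beyond the scatter, though the data constrain its size poorly. The expected step, a 50-fold lower number from compound 1 to compound 4 (1.70 log units; beyond the scatter), is large and toward a lower number. For compound 4 the estimate is 100 nM, with an expected range of 10 nM to 2000 nM.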

Compound 4, half-maximal inhibitory concentration: 3 nM
Compound 4: the middle estimate sits 33-fold (1.52 log units) above what was measured, and the stated range ends above it.
By their numbers in this assay, from the lowest: compound 4; then compounds 1, 2 and 3 (each within the scatter of the next, the first and the last beyond it).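

In this assay, methoxy in place of fluoro on an aromatic carbon, ortho to an amino group and para to a large group, gives a 1700-fold lower number from compound 1 to compound 4 (3.22 log units; beyond the scatter). Within the data shown here, this is the only single-place step, and it shows that the group at this position has a large bearing on the read-out, with the rest of the core of compound 1 unchanged. Nothing available explains the size of this step.

Going by these compounds, whether the effect is specific to methoxy, or would also appear with ethoxy, hydroxyl or chloro at this position, remains open. Also open, on these data alone, is whether the step depends on the neighbouring amino group, or would persist on the same core with an acetamide or a hydrogen in its place.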